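The source may hold more compounds than are shown below. What is called first, only, known or untested is meant among the compounds shown, and "the series" means these compounds.

Series notes. Compound 1 `COc1ncnc2c1c(-c1cccs1)cn2[C@@H]1O[C@H](CO)[C@@H](O)[C@H]1O`, compound 2 `CNc1ncnc2c1c(-c1cccs1)cn2[C@@H]1O[C@H](CO)[C@@H](O)[C@H]1O` and compound 3 `CNc1ncnc2c1c(-c1ccco1)cn2[C@@H]1O[C@H](CO)[C@@H](O)[C@H]1O` have been run in a functional assay on K562 cells (Homo sapiens), read by MTT assay, with a stated time of 72 h; a lower number here means a stronger inhibitor, a higher number a weaker inhibitor; compound 4 `COc1ncnc2c1c(-c1ccco1)cn2[C@@H]1O[C@H](CO)[C@@H](O)[C@H]1O` has not. In this assay compound 1 gives 70 nM and compound 3 gives 220 nM. Compound 2 gives > 20000 nM, which is a limit of the assay (the limit of > 20000 nM in this assay, at which 1 of the 3 values shown sits). The step of an at least 280-fold lower number from compound 2 to compound 1 (2.45 log units; beyond the scatter) goes with methoxy in place of methylamino on an aromatic carbon. The step of an at least 90-fold lower number from compound 2 to compound 3 (1.95 log units; beyond the scatter) goes with furan-2-yl in place of thiophen-2-yl on an aromatic carbon, which is also how the core of compound 3 differs from the core of compound 2. Compound 4 carries the same change as compound 1, (methoxy in place of methylamino on an aromatic carbon), at a place described in the same words. Since the earlier step starts from a limit, its full size is not known, so a smaller step of a 4.4-fold lower number from compound 3 to compound 4 (0.64 log units; beyond the scatter) is expected, resting on the step of an at least 280-fold lower number from compound 2 to compound 1 (2.45 log units; beyond the scatter). Compound 4 is expected at about 50 nM, between 10 nM and 300 nM.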

Compound 4, half-maximal inhibitory concentration: 60 nM
Compound 4: middle estimate off by 1.2-fold (0.08 log units), on the low side; low and high end bracket the measured number.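

In this assay, methoxy in place of methylamino gives a 3.7-fold lower number from compound 3 to compound 4 (0.56 log units; beyond the scatter), so the change keeps its direction on the second core but not its size: the same change on two cores in this assay, an at least 280-fold lower number (2.45 log units; beyond the scatter) from compound 2 to compound 1 and a 3.7-fold lower number (0.56 log units; beyond the scatter) from compound 3 to compound 4, at least 77-fold (1.89 log units) apart, beyond the scatter of two such steps

With methoxy in place, furan-2-yl in place of thiophen-2-yl gives a 1.2-fold lower number from compound 1 to compound 4 (0.07 log units; within the scatter), so this change does not carry over at a fixed size either: the same change on two cores in this assay, an at least 90-fold lower number (1.95 log units; beyond the scatter) from compound 2 to compound 3 and a 1.2-fold lower number (0.07 log units; within the scatter) from compound 1 to compound 4, at least 77-fold (1.89 log units) apart, beyond the scatter of two such steps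

Compound 2 gives > 20000 nM, a limit of the assay, so the full size of both earlier steps stays unknown, and the series shows that the size of each change depends on the group at the other place, not why: the limit of > 20000 nM in this assay, at which 1 of the 4 values shown sits.

On these data alone, it stays open whether the weak result of compound 2 belongs only to methylamino paired with thiophen-2-yl. As far as these compounds go, whether an unsubstituted amine, an ethoxy group or a longer chain in place of methoxy, or a phenyl ring in place of furan-2-yl, would follow the same pattern also stays open.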